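From benzyl to 4-methylbenzyl: one small step

The source may report more compounds than this note shows. Statements on the series, on what has been measured and on what is new or still open speak of the compounds shown alone.

Measured so far in a functional assay on SPCA2 cells (Homo sapiens) for cytotoxicity, read by MTT assay, with a stated time of 2 days; a lower number here means a stronger inhibitor, a higher number a weaker inhibitor
- compound 1 `O/N=C1/C(c2c[nH]c3ccc(OCc4ccccc4)cc23)=Nc2ccc(OCc3ccccc3)cc21` gives 12000 nM
- compound 2 `O=[N+]([O-])c1ccc2c(c1)/C(=N\O)C(c1c[nH]c3ccc([N+](=O)[O-])cc13)=N2` gives 11200 nM
- compound 3 `c1ccc(CO/N=C2/C(c3c[nH]c4ccccc34)=Nc3ccccc32)cc1` gives 21400 nM

All three numbers lie within the usual scatter of one another, so repeat measurements alone could produce gaps of this size. Compound 3 (21400 nM) therefore has no clear rank in this small set, and its value is best read simply as one of three that cannot be told apart.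

The next compound is compound 4 `Cc1ccc(CO/N=C2/C(c3c[nH]c4ccccc34)=Nc3ccccc32)cc1`, which differs from compound 3 in one place only: methyl in place of hydrogen on an aromatic carbon. This is methyl in place of hydrogen on an aromatic carbon, para to a large group, so that benzyl becomes 4-methylbenzyl.

For the measured compounds named here, no two measured compounds differ by a single change, so the data give no direct measure of what such a step does in this assay. Going by the values given here, the only guide is that the three measured values stay close together even though their structures differ. On that basis, no shift beyond the scatter is expected, and no direction is favoured with any confidence. The estimated change, a 1.2-fold lower number from compound 3 to compound 4 (0.08 log units; within the scatter), is accordingly expected to be small. For compound 4 the expected value is 18000 nM, with an estimated range from 8000 nM to 40000 nM.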

Compound 4, half-maximal inhibitory concentration: 25400 nM
For compound 4 the middle estimate is 1.4-fold (0.15 log units) below the measured one; low and high end bracket the measured number.
By their numbers in this assay, from the lowest: compounds 2, 1, 3 and 4 (each within the scatter of the next, the first and the last beyond it).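

For the compounds shown here, compound 3 and compound 4 form the first pair here that differs in one place, so they give the first direct reading of a single change: in this assay, methyl in place of hydrogen on an aromatic carbon, para to a large group, gives a 1.2-fold higher number from compound 3 to compound 4 (0.07 log units; within the scatter) and so leaves the two compounds indistinguishable. At this position of the benzyl group, then, adding one methyl has no effect that this assay can resolve, which is a statement about this one small group and nothing wider. No separate measurement bears on this result, and its cause cannot be stated.

On these data alone, it remains open whether a different group at the same place, such as an amine, a carboxylic acid or a longer chain like butyl, would shift the number beyond the usual scatter, since methyl alone says little about larger or charged replacements. Also open, as far as these compounds go, is whether the same methyl would behave alike elsewhere on these molecules, for instance on the shared core, where no single change can yet be read.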